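A few compounds are considered here, and "the series" means these few. Any claim that something is new, unique, unknown or untested is made for them only; others in the source may bear on it.

Among the measured compounds shown here, compound 2 `CN1C[C@H](C(=O)Nc2cccc(F)c2)[C@@H](c2ccc(/C=C/C(=O)Nc3ccccc3N)cc2)C1` holds the lowest of the two numbers so far in an in vitro ADME assay on microsomes from liver (Homo sapiens) for pharmacokinetics, read by LC-MS, with a stated time of 10 min, tested at 1 uM; a lower number here means slower removal, a higher number faster removal of the compound: compound 2 gives 6 mL/min/kg. Its nearest neighbour is compound 1 `CC(C)c1ccc(NC(=O)[C@H]2CN(C)C[C@@H]2c2ccc(/C=C/C(=O)Nc3ccccc3N)cc2)cc1`, which in this assay gives 10 mL/min/kg; the step of a 1.7-fold lower number from compound 1 to compound 2 (0.22 log units; within the scatter) lies within the scatter. Compound 3 `CN1C[C@H](C(=O)Nc2ccc(Cl)cc2F)[C@@H](c2ccc(/C=C/C(=O)Nc3ccccc3N)cc2)C1` has not yet been run in this assay. Its difference from compound 2 is 4-chloro-2-fluorophenyl in place of 3-fluorophenyl on an amide-type nitrogen. For the measured compounds named here, the one measured step that bears on this is the aryl swap on the same amide-type nitrogen, a 1.7-fold lower number from compound 1 to compound 2 (0.22 log units; within the scatter), which did not move the number beyond the scatter. Going by the values given here, the entering 4-chloro-2-fluorophenyl also carries chlorine, and no measured step covers a chlorine change, so nothing firmer can be drawn. The expected step is therefore a 1.2-fold higher number from compound 2 to compound 3 (0.07 log units; within the scatter), none beyond the scatter. Compound 3 is estimated at 7 mL/min/kg, with a range from 3.5 mL/min/kg to 14 mL/min/kg.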

Compound 3, clearance: 11 mL/min/kg
Compound 3: the middle estimate sits 1.6-fold (0.20 log units) below what was measured, and the stated range covers the measured number.
By their numbers in this assay, from the lowest: compounds 2, 1 and 3 (each within the scatter of the next).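

In this assay, the step to a chlorine-bearing aryl group on the amide-type nitrogen reads a 1.8-fold higher number from compound 2 to compound 3 (0.26 log units; within the scatter), and the comparison with the 4-isopropylphenyl compound reads a 1.1-fold higher number from compound 1 to compound 3 (0.04 log units; within the scatter). The 3-fluorophenyl, 4-isopropylphenyl and 4-chloro-2-fluorophenyl groups therefore give numbers within the scatter of one another, so this position shows no separation among these three aryl groups, including the first with chlorine. No supporting measurement accounts for these numbers.

Still open, going by these compounds, is whether a group of another kind on this nitrogen, such as a phenyl ring carrying a carboxylic acid or a dimethylamino group, or a cyclohexyl ring in place of the phenyl ring, would give a step beyond the scatter. Changes elsewhere on the shared core also remain open.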